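The source may report more compounds than this note shows. Statements on the series, on what has been measured and on what is new or still open speak of the compounds shown alone.

For the measured compounds named here, compound 2 `O=C1/C(=C\c2cccc(Br)c2)c2ccccc2N1c1c(Cl)cccc1Cl` is the only compound with a number in a functional assay on L132 cells (Homo sapiens) for cytotoxicity, read by MTT assay, with a stated time of 72 h (a lower number here means that less compound is needed, a higher number that more compound is needed for the effect), where compound 2 gives 19 ug/mL. Compound 1 `O=C1/C(=C\c2c(Cl)cccc2Cl)c2ccccc2N1c1c(Cl)cccc1Cl` shows in this assay only a limit, > 100 ug/mL. The step of an at least 5.2-fold lower number from compound 1 to compound 2 (0.72 log units; beyond the scatter) is therefore itself a bound, resting on (the limit of > 100 ug/mL in this assay, at which 1 of the 2 values shown sits). Compound 3 `O=C1/C(=C\c2ccccc2[N+](=O)[O-])c2ccccc2N1c1c(Cl)cccc1Cl` differs from compound 2 by 2-nitrophenyl in place of 3-bromophenyl on a double-bonded chain carbon bound to a double-bonded ring carbon. Going by the values given here, the one measured step concerns a different swap of ring substituents at the same place and sets only a bound, so it bears on this change only loosely. Compound 3 is expected to give an estimated 30 ug/mL in this assay, ranging from 8 ug/mL to 100 ug/mL. That expectation amounts to a step of a 1.6-fold higher number from compound 2 to compound 3 (0.20 log units; within the scatter).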

Compound 3, concentration for half-maximal effect: 10 ug/mL
The estimate for compound 3 lay 3.0-fold (0.48 log units) above the measured number; measured number inside the range.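

In this assay, the change at this place gives a 1.9-fold lower number from compound 2 to compound 3 (0.28 log units; within the scatter), so 2-nitrophenyl and 3-bromophenyl cannot be separated here, although only 2-nitrophenyl carries hydrogen-bond acceptors. The 2,6-dichlorophenyl compound stands apart from this pair, with an at least 10-fold lower number from compound 1 to compound 3 (1.00 log units; beyond the scatter). That step is only a bound, as compound 1 shows a limit and not a number: the limit of > 100 ug/mL in this assay, at which 1 of the 3 values shown sits.

The compounds shown leave open whether an aminophenyl or a carboxyphenyl group at this place would move the number beyond the scatter. They also leave open how a plain phenyl group would compare.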